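This account rests on a few compounds, and the source may have more. Where it says the series, first, only, none or still open, it means among the compounds named here.

The measured compounds:
Compound 1, `O=C(/C(=C\c1cccc(Cl)c1Cl)SCc1ccc(Cl)cc1)c1ccc(Cl)cc1`, gives 10000 nM in a functional assay on DU-145 cells (Homo sapiens) for inhibition, read by trypan blue exclusion, with a stated time of 96 h; on this read-out lower numbers stand for stronger inhibition of growth and higher numbers for weaker inhibition of growth.
Compound 2, `O=C(/C(=C\c1cccc(Cl)c1Cl)SCc1ccc(Cl)cc1)c1ccc(Br)cc1`, gives 10000 nM.
Compound 3, `Cc1ccc(CS/C(=C/c2cccc(Cl)c2Cl)C(=O)c2ccc(Cl)cc2)cc1`, gives 25000 nM.

Compound 1 stands level with compound 2 at the digits reported, and the two together give the lowest numbers of the three. Its nearest neighbour is compound 2, with no change at the digits printed from compound 1 to compound 2 (within the scatter), and its furthest is compound 3, with a 2.5-fold higher number from compound 1 to compound 3 (0.40 log units; beyond the scatter). Compound 4, `Cc1ccc(C)c(/C=C(/SCc2ccc(Cl)cc2)C(=O)c2ccc(Cl)cc2)c1`, has not yet been measured. It differs from compound 1 in a single place: 2,5-dimethylphenyl in place of 2,3-dichlorophenyl on a double-bonded chain carbon bound to a double-bonded chain carbon.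

Within the data shown here, neither measured step touches the ring that is exchanged here, so there is no direct precedent. The step that comes closest in kind is a 2.5-fold higher number from compound 1 to compound 3 (0.40 log units; beyond the scatter), where methyl in place of chloro on an aromatic carbon brought a modest weakening, whereas no change at the digits printed from compound 1 to compound 2 (within the scatter) shows that bromo in place of chloro left the number unchanged. Since the whole ring is exchanged and methyl again enters where chloro leaves, a modest weakening rather than no change is expected. Compound 4 is therefore expected to give 20000 nM, with a range of 8000 nM to 60000 nM. This amounts to an expected 2.0-fold higher number from compound 1 to compound 4 (0.30 log units; within the scatter).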

Compound 4, concentration for 50% growth inhibition: 10000 nM
Compound 4: middle estimate off by 2.0-fold (0.30 log units), on the high side, within the range that was stated.
By their numbers in this assay, from the lowest: compounds 1, 2 and 4 (each within the scatter of the next); then compound 3.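

In this assay, the whole ring on the double-bonded chain carbon could be exchanged with no measurable cost: the step is no change at the digits printed from compound 1 to compound 4 (within the scatter). This shows that chlorine on the ring at this place is not needed to hold the number, since 2,5-dimethylphenyl serves as well as 2,3-dichlorophenyl. The earlier methyl-for-chloro step, a 2.5-fold higher number from compound 1 to compound 3 (0.40 log units; beyond the scatter), therefore does not carry over to this place, and nothing available bears on why the two exchanges read differently.

As far as these compounds go, all four compounds carry a carbon-only aromatic ring at this place, substituted with chloro or methyl groups, so it remains open whether an amine, a carboxylic acid or a methoxy group on that ring would hold the number as well. From the compounds shown here alone, compound 1 gives 10000 nM, and it also remains open whether any other group at this place, such as a longer chain in place of the ring, would move the number clearly lower or higher than that.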